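The source may hold more compounds than are shown below. What is called first, only, known or untested is meant among the compounds shown, and "the series" means these compounds.

Of the four compounds in this set, compound 1 `CCN(Cc1ccccc1)C(=O)C1CCN(S(=O)(=O)c2c(C)noc2C)CC1` has in a functional assay on CHO cells for positive allosteric modulation of muscarinic acetylcholine receptor M5 (Homo sapiens), read by calcium flux (a lower number here means a smaller maximal response, a higher number a larger maximal response), only the entry "not determined" (no result reported), and compound 2 `CCN(Cc1ccccc1)C(=O)C1CCN(S(=O)(=O)c2cccc3nsnc23)CC1` has the entry "not determined" (no result reported). Among the measured compounds shown here, compound 3 `CCN(Cc1ccc(F)cc1)C(=O)C1CCN(S(=O)(=O)c2ccc3cn[nH]c3c2)CC1` is thus the only one with a number: in this assay compound 3 gives 55%, a middling maximal response, and with nothing measured beside it no step between measured compounds can be drawn. Compound 4 `CCN(Cc1cccc(C)c1)C(=O)C1CCN(S(=O)(=O)c2ccc3cn[nH]c3c2)CC1` differs from compound 3 in a single place: 3-methylphenyl in place of 4-fluorophenyl on a saturated chain carbon bound to an amide-type nitrogen. For the measured compounds named here, no measured pair shows what such an exchange does in this assay, so the expectation rests on compound 3 alone. The step from compound 3 to compound 4 is expected to be no change at the digits printed from compound 3 to compound 4 (within the scatter), with no direction that reaches beyond the usual scatter. Compound 4 is accordingly estimated at 55%, between 30% and 80%.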

Compound 4, largest response reached (reported as percent of maximum), in percent of the reference or control that the assay uses: 78%
Estimate against measurement, compound 4: 23 percentage points below, within the range that was stated.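

With 3-methylphenyl in place of 4-fluorophenyl on a saturated chain carbon bound to an amide-type nitrogen, this assay shows a number 23 percentage points higher from compound 3 to compound 4 (beyond the scatter). Among the compounds shown here, this is the first readable step in the set, and it shows that the maximal response is sensitive to the group at this position, while the rest of the molecule stays the same. No measurement given here explains the step. The exchange alters both the substituent and where it stands, so 4-methylphenyl and 3-fluorophenyl would be needed to separate the two. Going by these compounds, how a 3-methoxyphenyl or a pyridyl group would behave at this position remains open.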